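Fluorine on the benzyl ring of two oxime ether pairs

The compounds below may be only part of what the source reports. "The series", "measured", "known", "first", "only" and "open" are said of these compounds alone.

Compound 1 `O=[N+]([O-])c1cc(C(F)(F)F)cc([N+](=O)[O-])c1Oc1ccc(Cl)cc1/C=N\OCc1ccccc1` gives 3410 nM in a functional assay on A549 cells (Homo sapiens) for antiproliferative activity, read by MTT assay, with a stated time of 48 h; a lower number here means a stronger inhibitor, a higher number a weaker inhibitor.
Compound 2 `O=[N+]([O-])c1cc(C(F)(F)F)cc([N+](=O)[O-])c1Oc1ccc(Cl)cc1/C=N\OCc1ccccc1F` gives 2570 nM in this assay.
Compound 3 `O=[N+]([O-])c1cc(C(F)(F)F)cc([N+](=O)[O-])c1Oc1c(Br)cc(Br)cc1/C=N\OCc1ccccc1` gives 2150 nM in this assay.

The three measured compounds share the same dinitro-trifluoromethylphenyl ether and oxime ether arrangement and differ only in the substituted aromatic rings. Compound 1 and compound 2 differ in one place: fluoro in place of hydrogen on an aromatic carbon. This change produced a 1.3-fold lower number from compound 1 to compound 2 (0.12 log units; within the scatter). Compound 3 carries a different core from compound 1; the difference between the two cores is not broken down here. Its value and those of compound 1 and compound 2 all lie within the scatter of one another, so no order among the three can be stated.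

Compound 4 `O=[N+]([O-])c1cc(C(F)(F)F)cc([N+](=O)[O-])c1Oc1c(Br)cc(Br)cc1/C=N\OCc1ccccc1F` has not yet been measured. It stands to compound 3 as compound 2 stands to compound 1: the difference is fluoro in place of hydrogen on an aromatic carbon, the same change as from compound 1 to compound 2, placed on the same kind of aromatic carbon. Because the earlier step was a 1.3-fold lower number from compound 1 to compound 2 (0.12 log units; within the scatter), the expectation for compound 4 is a step of about the same size from compound 3, a 1.3-fold lower number from compound 3 to compound 4 (0.10 log units; within the scatter), which itself falls within the scatter. On that basis compound 4 is estimated at 1700 nM in this assay, most likely between 900 nM and 3500 nM.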

Compound 4, half-maximal inhibitory concentration: 1560 nM
Compound 4: middle estimate off by 1.1-fold (0.04 log units), on the high side, and the stated range covers the measured number.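

Fluoro in place of hydrogen on the core of compound 3 gives a 1.4-fold lower number from compound 3 to compound 4 (0.14 log units; within the scatter) in this assay. Set beside the step on the core of compound 1, the change reads alike on the two cores: the same change on two cores in this assay, a 1.3-fold lower number (0.12 log units; within the scatter) from compound 1 to compound 2 and a 1.4-fold lower number (0.14 log units; within the scatter) from compound 3 to compound 4, 1.0-fold (0.02 log units) apart, within the scatter of two such steps
This shows that, across these two pairs, the change carries from one core to the other without any detectable difference in its step, but it does not show that the change itself does anything to the number, since each step lies within the scatter on its own, and two cores are too few to support a rule for the whole series.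

The compounds shown leave open whether a chloro, a methoxy group or an amine in place of that same hydrogen would give a step that could be read beyond the scatter, and whether a longer chain in place of the benzyl group would leave the number where it stands. They also leave open whether the close match between the two steps would hold on any core other than these two, or in any assay other than this assay.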